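Swapping Fluoro for Bromo in a Small Cytotoxic Series

The compounds below may be only part of what the source reports. "The series", "measured", "known", "first", "only" and "open" are said of these compounds alone.

Three related compounds have been tested so far in a functional assay on HeLa cells (Homo sapiens) for cytotoxicity, read by MTT assay, with a stated time of 24 h; on this read-out higher numbers stand for weaker inhibition and lower numbers for stronger inhibition. Compound 1 `COc1ccc(/C=C2\CN(C)C/C(=C\c3ccccc3F)C2=O)cc1` gives 23500 nM, compound 2 `COc1cc(/C=C2\CN(C)C/C(=C\c3ccccc3F)C2=O)cc(OC)c1OC` gives 3220 nM, and compound 3 `COc1cc(/C=C2\CN(C)C/C(=C\c3ccc(F)cc3)C2=O)cc(OC)c1` gives 10200 nM. Compound 3 therefore holds the middle place of the three. Its number is lower than that of compound 1 and higher than that of compound 2, and both gaps lie beyond the usual scatter of repeated measurements.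

The next compound, compound 4 `COc1cc(/C=C2\CN(C)C/C(=C\c3ccc(Br)cc3)C2=O)cc(OC)c1`, keeps everything in compound 3 except one substituent: bromo in place of fluoro on an aromatic carbon. Put simply, a 4-fluorophenyl becomes a 4-bromophenyl.

Going by the values given here, no two measured compounds differ in only one place, so the data give no direct guide to the size of this swap. The best anchor is compound 3 itself, at 10200 nM, and a small shift towards a lower number in this assay is expected, with nothing beyond the scatter. The expected change is a 1.4-fold lower number from compound 3 to compound 4 (0.13 log units; within the scatter). For compound 4 the estimated value is 7500 nM, with an expected range from 3000 nM to 19000 nM.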

Compound 4, half-maximal inhibitory concentration: 5900 nM
The estimate for compound 4 lay 1.3-fold (0.10 log units) above the measured number; low and high end bracket the measured number.
By their numbers in this assay, from the lowest: compounds 2, 4 and 3 (each within the scatter of the next, the first and the last beyond it); then compound 1.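

Going by these compounds alone, this is the first pair that differs in one place only, so the effect of a single change can now be read directly: in this assay, bromo in place of fluoro on an aromatic carbon gives a 1.7-fold lower number from compound 3 to compound 4 (0.24 log units; within the scatter). For this one pair, then, the 4-fluorophenyl and the 4-bromophenyl cannot be told apart in this measurement, since one halogen atom can replace the other without a step beyond the scatter. No separate measurement is available that could explain the size of this step.

What the compounds leave open is how much this position matters, since the two groups seen there are both single halogen atoms, and a quite different group there, such as an amine, a carboxylic acid or a longer chain like butyl, might give a much larger step or a very similar one. As far as these compounds go, it also remains open whether the same swap from fluoro to bromo would give a step of similar size in compound 1 or compound 2, which carry other substituents on their rings.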